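The source may hold more compounds than are shown below. What is called first, only, known or untested is meant among the compounds shown, and "the series" means these compounds.

In a functional assay on Z-138 cells (Homo sapiens) for inhibition, read by luminescence and CellTiter-Glo, with a stated time of 72 h (a lower number here means a stronger inhibitor, a higher number a weaker inhibitor), two compounds have been measured:

compound 1 `O=C(CCl)Nc1cccc(Cn2nc(-c3ccc(Oc4ccccc4)cc3)cc2CO)c1` gives 400 nM
compound 2 `C=CC(=O)Nc1cccc(Cn2nc(-c3ccc(Oc4ccccc4)cc3)cc2CO)c1` gives 6000 nM

Among the measured compounds shown here, compound 1 has the lowest number of the two, and the only measured step, a 15-fold higher number from compound 1 to compound 2 (1.18 log units; beyond the scatter), is a vinyl in place of chloromethyl on a carbonyl carbon. Compound 3 `O=C(CCl)Nc1cccc(Cn2nc(-c3ccc(Oc4ccccc4)cc3)cc2C(=O)O)c1` differs from compound 1 by carboxy in place of hydroxymethyl on an aromatic carbon. For the measured compounds named here, no measured step bears on this change, so the direction and size of the step in this assay are unknown, and the estimate is set wide. Compound 3 is expected at 1500 nM, with a range of 300 nM to 8000 nM, meaning an expected step of a 3.8-fold higher number from compound 1 to compound 3 (0.57 log units; beyond the scatter).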

Compound 3, half-maximal inhibitory concentration: 9100 nM
Compound 3: middle estimate off by 6.1-fold (0.78 log units), on the low side, outside the stated range (above it).
By their numbers in this assay, from the lowest: compound 1; then compounds 2 and 3 (each within the scatter of the next).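

Among the compounds shown here, until now only the group on the carbonyl carbon had changed; this is the first change on the aromatic carbon that carries hydroxymethyl. In this assay carboxy there brings a 23-fold higher number from compound 1 to compound 3 (1.36 log units; beyond the scatter) and so this position does not tolerate every group, even though the swap adds little in size. Nothing available gives a reason for this step. Still open, as far as these compounds go, is whether a methyl ester, a primary amide or an aminomethyl group here would stay close to compound 1. Also open, from the compounds shown here alone, is whether carboxy would have the same effect alongside the vinyl group of compound 2.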